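Methoxy placement in an amide series: cytotoxicity notes

The source may hold more compounds than are shown below. What is called first, only, known or untested is meant among the compounds shown, and "the series" means these compounds.

Compound 1 `COc1cc(NC(=O)/C=C/c2ccccc2)cc(OC)c1OC` and compound 2 `COc1cc(/C=C/C(=O)Nc2ccccc2)cc(OC)c1OC` are built from the same atoms joined differently; the difference between the two cores is not broken down here. In a functional assay on HeLa cells (Homo sapiens) for cytotoxicity, read by sulforhodamine B assay, with a stated time of 72 h (on this read-out lower numbers stand for stronger inhibition and higher numbers for weaker inhibition), compound 1 gives only a limit of > 50000 nM and no number. Compound 2 is likewise reported in this assay only as a limit of > 50000 nM. Compound 3 `COc1ccc(NC(=O)/C=C/c2cc(OC)c(OC)c(OC)c2)cc1` carries, relative to compound 2, (methoxy in place of hydrogen on an aromatic carbon). In this assay compound 3 is also reported only as a limit of > 50000 nM. The step that the two limits leave unreadable from compound 2 to compound 3 cannot be read, because all three values sit at the limit of > 50000 nM in this assay, at which 3 of the 3 values shown sit.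

Compound 4 `COc1ccccc1/C=C/C(=O)Nc1cc(OC)c(OC)c(OC)c1` has not been measured. It differs from compound 1 by methoxy in place of hydrogen on an aromatic carbon. This is the same kind of change as that from compound 2 to compound 3, but the place is not the same: in compound 3 the entering methoxy sits para to a large group, whereas in compound 4 it sits ortho to a large group. The earlier step gave no readable size, and compound 1 itself is reported only as a limit. On that basis the expected step is a step that the limit leaves unreadable from compound 1 to compound 4, which in practice means no readable change. Compound 4 is accordingly expected to give 90000 nM, with a range from 30000 nM to 300000 nM, and most probably to be reported only as a limit in this assay.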

Compound 4, half-maximal inhibitory concentration: 6100 nM
Estimate against measurement, compound 4: 15-fold (1.17 log units) above, outside the stated range (below it).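

Working notes on the methoxy change. In this assay, methoxy in place of hydrogen on an aromatic carbon, ortho to a large group, on the core of compound 1 gives an at least 8.1-fold lower number from compound 1 to compound 4 (0.91 log units; beyond the scatter), and this is a lower bound on the step, since one end of it is a limit. The same kind of change on the core of compound 2, made at a different place, cannot be read, because both of its ends are limits, and the same limit also holds for compound 1: the limit of > 50000 nM in this assay, at which 3 of the 4 values shown sit. The change therefore shows a readable effect on one core only; it does not show that the effect carries from one core to another, and with core and place both differing, a single readable step supports no rule for the series.

As far as these compounds go, the full size of the step remains open, as does whether methoxy ortho to a large group on the core of compound 2 would also give a readable step. Also open, from the compounds shown here alone, is whether the step belongs to methoxy itself or would appear with a hydroxy group, an amine or a longer chain such as ethoxy on the same aromatic carbon.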